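Removing a Methoxy Group on Two Different Cores

The source may report more compounds than this note shows. Statements on the series, on what has been measured and on what is new or still open speak of the compounds shown alone.

Compound 1 `COc1ccc(C(=O)NNC(=S)Nc2csc(-c3ccccc3)c2)cc1` and compound 2 `COc1ccc(C(=O)NNC(=S)Nc2csc(-c3ccccc3)c2)cc1OC` share one core, while compound 3 `COc1ccc(-c2cc(Nc3nnc(-c4ccc(C)cc4)s3)cs2)cc1` is built on another; the difference between the two cores is not broken down here. In a functional assay on MCF7 cells (Homo sapiens) for inhibition, read by colorimetric assay and MTT assay, with a stated time of 72 h (on this read-out higher numbers stand for weaker inhibition and lower numbers for stronger inhibition), compound 1 gives 32000 nM and compound 2 gives 21000 nM. The step of a 1.5-fold higher number from compound 2 to compound 1 (0.18 log units; within the scatter) is hydrogen in place of methoxy on an aromatic carbon. For compound 3 this assay reports only a limit, > 100000 nM, which is the limit of > 100000 nM in this assay, at which 1 of the 3 values shown sits. Compound 4 `Cc1ccc(-c2nnc(Nc3csc(-c4ccccc4)c3)s2)cc1` is not yet measured; it arises from compound 3 by hydrogen in place of methoxy on an aromatic carbon, the same kind of change as from compound 2 to compound 1, though here the place is para to a large group rather than ortho to a methoxy group and meta to a large group. The step that the limit leaves unreadable from compound 3 to compound 4 is expected to be small because the comparable step a 1.5-fold higher number from compound 2 to compound 1 (0.18 log units; within the scatter) stayed within the scatter. Compound 4 is therefore estimated at 150000 nM, between 60000 nM and 400000 nM, and this assay may again report only a limit.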

Compound 4, half-maximal inhibitory concentration: 34000 nM
Beside the measured number, compound 4's estimate is 4.4-fold (0.64 log units) above it, outside the stated range (below it).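

In this assay, replacing methoxy with hydrogen gives an at least 2.9-fold lower number from compound 3 to compound 4 (0.46 log units; beyond the scatter). Set beside the earlier step, the same change does not behave alike on the two cores: the same change on two cores in this assay, a 1.5-fold higher number (0.18 log units; within the scatter) from compound 2 to compound 1 and an at least 2.9-fold lower number (0.46 log units; beyond the scatter) from compound 3 to compound 4, at least 4.4-fold (0.65 log units) apart, beyond the scatter of two such steps For compound 3, > 100000 nM is a limit of the assay and not a number; the true size of its step therefore stays unknown, and two cores alone show neither why the steps differ nor what the change would do on a third core.

The compounds shown leave open what an amine, a hydroxyl group or a fluorine atom would do in place of methoxy on either core. Going by these compounds, a longer chain, such as ethoxy, remains open too.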